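The source may hold more compounds than are shown below. What is called first, only, known or untested is meant among the compounds shown, and "the series" means these compounds.

Of the compounds shown here, three have been measured so far. Compound 1 `Cc1ccc(NC(=S)NC(=O)c2ccc(OCc3ccc(C(F)(F)F)cc3)cc2)cc1-c1nc2ccccc2[nH]1` gives 10200 nM in a functional assay on MNK45 cells (Homo sapiens) for inhibition, read by MTT assay, with a stated time of 48 h; a higher number here means a weaker inhibitor, a lower number a stronger inhibitor. Compound 2 `Cc1ccc(NC(=S)NC(=O)c2ccc(OCc3cccc(C(F)(F)F)c3)cc2)cc1-c1nc2ccccc2[nH]1` gives 6050 nM in this assay, and compound 3 `O=C(NC(=S)Nc1ccc(Cl)c(-c2nc3ccccc3[nH]2)c1)c1ccc(OCc2ccc(C(F)(F)F)cc2)cc1` gives 7830 nM in this assay. Going by the values given here, compound 3 thus stands second highest among the numbers so far, with compound 2 nearest and compound 1 furthest, both gaps within the scatter. The two single-point steps are both small: a 1.7-fold lower number from compound 1 to compound 2 (0.23 log units; within the scatter), and a 1.3-fold lower number from compound 1 to compound 3 (0.11 log units; within the scatter).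

Compound 4 `O=C(NC(=S)Nc1ccc(Cl)c(-c2nc3ccccc3[nH]2)c1)c1ccc(OCc2ccc(Cl)cc2Cl)cc1` has not been measured. It differs from compound 3 in one place: 2,4-dichlorophenyl in place of 4-(trifluoromethyl)phenyl on a saturated chain carbon bound to an oxygen on an aromatic ring. Among the compounds with values here, only the step from compound 1 to compound 2 alters the group at this same place, and it stayed within the scatter; the step from compound 1 to compound 3 alters a different place. Within the data shown here, no measured compound carries a dichlorophenyl here. Compound 4 is therefore expected to give a number close to that of compound 3. The expected step is a 1.1-fold lower number from compound 3 to compound 4 (0.05 log units; within the scatter), within the scatter. The estimate for compound 4 in this assay is 7000 nM, within a range from 3000 nM to 16000 nM.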

Compound 4, half-maximal inhibitory concentration: 3750 nM
For compound 4 the middle estimate is 1.9-fold (0.27 log units) above the measured one, within the range that was stated.
By their numbers in this assay, from the lowest: compounds 4, 2, 3 and 1 (each within the scatter of the next, the first and the last beyond it).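

In this assay, going by these compounds alone, the 2,4-dichlorophenyl group is the first change in this set to move the number beyond the scatter at this place, if only modestly (a 2.1-fold lower number from compound 3 to compound 4 (0.32 log units; beyond the scatter)). The earlier change here, which shifted the trifluoromethyl group on the phenyl ring (a 1.7-fold lower number from compound 1 to compound 2 (0.23 log units; within the scatter)), stayed within the scatter, so this place is not wholly indifferent to what it carries. The result rests on one pair of compounds, and no measurement at hand accounts for the step.

The compounds shown do not tell whether both chlorines are needed for this step, or how a single chloro, a methoxy group or an amine on this phenyl ring would compare. From the compounds shown here alone, it also remains open whether the step would hold with methyl in place of chloro on the aromatic carbon of the core.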